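The source may hold more compounds than are shown below. What is called first, only, known or untested is meant among the compounds shown, and "the series" means these compounds.

Working notes on the series. The compounds share one core carrying a nitro group; compound 1 is `CC(=O)c1cccc(-c2nc3cc([N+](=O)[O-])ccc3[nH]2)c1` and compound 2 is `O=[N+]([O-])c1ccc2[nH]c(-c3ccc(C(F)(F)F)cc3)nc2c1`. In a functional assay for antagonist activity at Neuropeptides B/W receptor type 1 (Homo sapiens), read by cAMP accumulation (on this read-out higher numbers stand for weaker inhibition and lower numbers for stronger inhibition), compound 1 gives only a limit, > 31600 nM, and not a number. In this assay compound 2 likewise gives only a limit, > 31600 nM, and not a number. Going by the values given here, compound 2 therefore stands at the same limit as the one other value shown, so nothing in the numbers sets the two measured compounds apart; both sit at the limit of > 31600 nM in this assay, at which 2 of the 2 values shown sit. Among the compounds with values here, no step between measured compounds is available, since no two of them differ in a single place.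

Compound 3 is `CC(C)(C)c1ccc(-c2nc3cc([N+](=O)[O-])ccc3[nH]2)cc1`, still to be measured in this assay. It differs from compound 2 by tert-butyl in place of trifluoromethyl on an aromatic carbon.

With compound 2 sitting at a limit, the step is expected to be a step that the limit leaves unreadable from compound 2 to compound 3, that is, no movement beyond the scatter that the numbers can show. For compound 3 the estimate in this assay is 40000 nM, with a range from 10000 nM to 160000 nM, and a limit rather than a number is expected as the most likely outcome.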

Compound 3, half-maximal inhibitory concentration: 3180 nM
Estimate against measurement, compound 3: 13-fold (1.10 log units) above, and the stated range ends above it.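

Tert-butyl in place of trifluoromethyl on an aromatic carbon, para to a large group, gives an at least 9.9-fold lower number from compound 2 to compound 3 (0.99 log units; beyond the scatter) in this assay, the only step in the series that can be read. The group at this position therefore matters: compound 3 gives 3180 nM, a true number, which shows that the shared core with its nitro group can register in this assay. The limits of compound 1 and compound 2 alone could not show this. Compound 2 holds a limit and not a number, so the step gives only a lower bound on the size of the change: the limit of > 31600 nM in this assay, at which 2 of the 3 values shown sit.

The compounds shown leave open whether the gain is specific to tert-butyl, as the series offers no other group at this position, such as an amine, a carboxylic acid or a longer alkyl chain. Going by these compounds alone, they also leave open how far the result depends on the nitro group, as no compound here carries, for example, a nitrile in its place with tert-butyl kept.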